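A few compounds are considered here, and "the series" means these few. Any claim that something is new, unique, unknown or untested is made for them only; others in the source may bear on it.

The three measured compounds share one core and differ only in the aryl group on the amide-type nitrogen. Compound 1 `COc1cc(Cl)cc(-c2nn(-c3cccc(NC(=O)Nc4ccc(Cl)c(C(F)(F)F)c4)c3)cc2-c2ccncc2)c1` is tested in a functional assay on SF-268 cells (Homo sapiens) for inhibition, read by sulforhodamine B assay, with a stated time of 48 h, tested at 1 uM (a higher number here means a weaker effect of the compound at the concentration tested, a lower number a stronger effect), where compound 1 gives 83%. Compound 2 `COc1cc(Cl)cc(-c2nn(-c3cccc(NC(=O)Nc4cc(C(F)(F)F)cc(C(F)(F)F)c4)c3)cc2-c2ccncc2)c1` gives in this assay 37%. Compound 3 `COc1cc(Cl)cc(-c2nn(-c3cccc(NC(=O)Nc4ccc(Cl)c(Cl)c4)c3)cc2-c2ccncc2)c1` gives 88%. Compound 3 thus stands highest of the three numbers; its nearest neighbour is compound 1, and the step of a number 5 percentage points higher from compound 1 to compound 3 (within the scatter) lies within the scatter, so the two cannot be ordered. Compound 2 is furthest away, and its number lies beyond the scatter from that of compound 3.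

Compound 4 `COc1cc(Cl)cc(-c2nn(-c3cccc(NC(=O)Nc4cccc(C(F)(F)F)c4)c3)cc2-c2ccncc2)c1` has not yet been measured. The change from compound 3 is 3-(trifluoromethyl)phenyl in place of 3,4-dichlorophenyl on an amide-type nitrogen. For the measured compounds named here, no measured step makes this same exchange. Going by the values given here, the only single-site step known, a number 5 percentage points higher from compound 1 to compound 3 (within the scatter), swapped chloro for trifluoromethyl on an aromatic carbon and stayed within the scatter. Close to compound 3, compound 1 already carries trifluoromethyl on that aryl group and gives 83%, so the step expected is a number 3 percentage points lower from compound 3 to compound 4 (within the scatter), pointing in no direction beyond the scatter. Compound 4 is therefore estimated at 85%, in a range from 65% to 100%.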

Compound 4, a percentage reported as activity, at one concentration (the size of the read-out at that concentration, not a potency): 79%
Estimate against measurement, compound 4: 6 percentage points above; the measured number falls inside the stated range.
By their numbers in this assay, from the lowest: compound 2; then compounds 4, 1 and 3 (each within the scatter of the next).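

In this assay, replacing the 3,4-dichlorophenyl of compound 3 with 3-(trifluoromethyl)phenyl on the amide-type nitrogen gives no resolved change (a number 9 percentage points lower from compound 3 to compound 4 (within the scatter)), and hydrogen in place of chloro on the aryl group likewise gives none (a number 4 percentage points lower from compound 1 to compound 4 (within the scatter)). The first single-site comparison involving compound 2 gives a much larger result for hydrogen in place of trifluoromethyl (a number 42 percentage points higher from compound 2 to compound 4 (beyond the scatter)), so the second trifluoromethyl alone separates compound 2 from compound 4, whereas the chloro that separates compound 1 from compound 4 makes no resolved difference. No available evidence bears on what underlies this contrast between the two groups on the aryl ring.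

The compounds shown leave open whether another group in that same place on the aryl ring, such as a nitrile, a methoxy, an amine or a carboxylic acid, would give a step as large as trifluoromethyl does. They also leave open whether the large step would persist with a different group in place of the chloro or the methoxy on the other aryl ring of the shared core.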